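This account rests on a few compounds, and the source may have more. Where it says the series, first, only, none or still open, it means among the compounds named here.

Among the measured compounds shown here, compound 1 `CN(C)CCn1cnnc1-c1cc(Oc2ccc(NC(=O)N/N=C/c3c(Cl)cccc3Cl)cc2F)ccn1` gives 280 nM in a functional assay on HT-29 cells (Homo sapiens) for cytotoxicity, read by MTT assay, with a stated time of 72 h (on this read-out lower numbers stand for stronger inhibition and higher numbers for weaker inhibition), the lowest of the three numbers measured so far. Compound 2 `CN(C)CCn1cnnc1-c1cc(Oc2ccc(NC(=O)N/N=C/c3ccccc3O[N+](=O)[O-])cc2F)ccn1` gives 950 nM in this assay, and compound 3 `CN(C)CCn1cnnc1-c1cc(Oc2ccc(NC(=O)N/N=C/c3ccccc3)cc2F)ccn1` gives 1120 nM. Compound 4 `CN(C)CCn1cnnc1-c1cc(Oc2ccc(NC(=O)N/N=C/c3ccc(F)cc3)cc2F)ccn1` has not yet been measured; it differs from compound 1 in one place: 4-fluorophenyl in place of 2,6-dichlorophenyl on a carbon with a double bond to nitrogen. For the measured compounds named here, two measured steps bear on this change, as both of them also replace the 2,6-dichlorophenyl of compound 1 with another ring on the same carbon. The step of a 3.4-fold higher number from compound 1 to compound 2 (0.53 log units; beyond the scatter) and the step of a 4.0-fold higher number from compound 1 to compound 3 (0.60 log units; beyond the scatter) were both modest and both went toward weaker inhibition. The step of a 1.2-fold higher number from compound 2 to compound 3 (0.07 log units; within the scatter) lies within the scatter, so the two rings without the chlorines gave much the same result. Compound 4 carries 4-fluorophenyl, which resembles the phenyl of compound 3 more than the 2,6-dichlorophenyl of compound 1. A modest step toward a higher number, a 3.6-fold higher number from compound 1 to compound 4 (0.55 log units; beyond the scatter), is therefore expected. Compound 4 is estimated at 1000 nM, within a range of 450 nM to 2300 nM.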

Compound 4, half-maximal inhibitory concentration: 1370 nM
The estimate for compound 4 lay 1.4-fold (0.14 log units) below the measured number, and the stated range covers the measured number.
By their numbers in this assay, from the lowest: compound 1; then compounds 2, 3 and 4 (each within the scatter of the next).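

In this assay, the step of a 4.9-fold higher number from compound 1 to compound 4 (0.69 log units; beyond the scatter) adds a third ring without chlorine that gives a higher number than the 2,6-dichlorophenyl of compound 1, so on this carbon that ring stands apart from all three replacements shown. Among those replacements, the step of a 1.2-fold higher number from compound 3 to compound 4 (0.09 log units; within the scatter) shows no readable effect of fluoro in place of hydrogen on an aromatic carbon, and the step of a 1.4-fold higher number from compound 2 to compound 4 (0.16 log units; within the scatter) leaves 4-fluorophenyl and 2-(nitrooxy)phenyl indistinguishable as well. No evidence is given that would explain these results.

Still open, on these data alone, is whether both chlorines are needed, or whether a phenyl ring carrying a single chlorine would match compound 1. As far as these compounds go, it is also open whether two bromine atoms or two methyl groups could take the place of the two chlorines.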